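A few compounds are considered here, and "the series" means these few. Any claim that something is new, unique, unknown or untested is made for them only; others in the source may bear on it.

For the measured compounds named here, compound 1, `N#CC1=C(NC(=O)c2ccccc2)N(c2ccc(S(N)(=O)=O)cc2)C2=C(C(=O)CCC2)C1c1ccc(Cl)cc1Cl`, is the reference point for the two compounds measured so far. In a functional assay on Ehrlich cells (Mus musculus) for cytotoxicity, read by trypan blue exclusion, with a stated time of 2 h, tested at 50 ug/mL (a lower number here means a weaker effect, a higher number a stronger effect of the compound at the concentration tested), compound 1 gives 70%, the highest of the two numbers in hand. Going by the values given here, compound 2, `CN(C)c1ccc(/C=C/C=N/C2=C(C#N)C(c3ccc(Cl)cc3Cl)C3=C(CCCC3=O)N2c2ccc(S(N)(=O)=O)cc2)cc1`, is the only other measured compound; in this assay compound 2 gives 20%, a number far below that of compound 1 and beyond the scatter. Among the compounds with values here, no single-point step between compound 1 and compound 2 is available, so their two values stand on their own.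

Compound 3, `CC(=O)CC(=O)NC1=C(C#N)C(c2ccc(Cl)cc2Cl)C2=C(CCCC2=O)N1c1ccc(S(N)(=O)=O)cc1`, has not yet been measured. It differs from compound 1 in one place: 2-oxopropyl in place of phenyl on a carbonyl carbon. Within the data shown here, no measured pair isolates a change on this carbonyl carbon, so the size of the step rests on the two values alone. The expected step is a number 20 percentage points lower from compound 1 to compound 3 (beyond the scatter), a modest weakening in this assay, with wide uncertainty because only compound 1 at 70% anchors this position. Compound 3 is estimated at 50% in this assay, within a range from 25% to 75%.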

Compound 3, a percentage reported as activity, at one concentration (the size of the read-out at that concentration, not a potency): 60%
The estimate for compound 3 lay 10 percentage points below the measured number; low and high end bracket the measured number.
By their numbers in this assay, from the lowest: compound 2; then compounds 3 and 1 (each within the scatter of the next).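

In this assay, for the compounds shown here, 2-oxopropyl in place of phenyl on a carbonyl carbon gives a number 10 percentage points lower from compound 1 to compound 3 (within the scatter) and is the first change at this position that can be read. With the rest of compound 1 kept, the read-out therefore does not depend on an aromatic ring at this position: an open chain with a ketone carbonyl, which adds a hydrogen-bond acceptor, serves within the scatter as well as the phenyl group does, at least for this one pair. No available measurement explains why the two groups read alike, and no property can be assigned to either of them.

Still open, as far as these compounds go, is how far this position accepts other groups, such as a longer chain, a terminal amine or a carboxylic acid on the same carbonyl carbon, and whether any of these would move the read-out beyond the scatter. The read-out also comes from a single tested concentration and gives no potency, so it leaves open whether compound 1 and compound 3 would still read alike across a range of concentrations.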